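One Substitution on a Carbonyl Carbon, Outcome Still Expected

The source may report more compounds than this note shows. Statements on the series, on what has been measured and on what is new or still open speak of the compounds shown alone.

Compound 1 `Cc1ccsc1/C=C(/SCc1ccc(F)cc1)C(=O)c1ccc(Br)cc1`: 50000 nM
Compound 2 `O=C(/C(=C\c1ccc([N+](=O)[O-])c(O)c1)SCc1ccc(Br)cc1)c1cc(Cl)ccc1O`: 10000 nM

In a functional assay on DU-145 cells (Homo sapiens) for inhibition, read by trypan blue exclusion, with a stated time of 96 h (on this read-out lower numbers stand for stronger inhibition of growth and higher numbers for weaker inhibition of growth), compound 2 gives 10000 nM, the lowest of the two numbers. Compound 1 gives 50000 nM in this assay, a higher number beyond the scatter. Compound 3 `O=C(/C(=C\c1ccc([N+](=O)[O-])c(O)c1)SCc1ccc(Br)cc1)c1ccc([N+](=O)[O-])c(Cl)c1` has not been measured. It differs from compound 2 in one place: 3-chloro-4-nitrophenyl in place of 5-chloro-2-hydroxyphenyl on a carbonyl carbon. Going by the values given here, no measured pair here differs in one place, so this change has no precedent in these data. The expected step is no change at the digits printed from compound 2 to compound 3 (within the scatter), not beyond the scatter. Compound 3 is estimated to give 10000 nM in this assay, with a range from 3000 nM to 35000 nM.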

Compound 3, concentration for 50% growth inhibition: 1000 nM
Beside the measured number, compound 3's estimate is 10-fold (1.00 log units) above it, and the stated range ends above it.
By their numbers in this assay, from the lowest: compound 3; then compound 2; then compound 1.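

In this assay, going by these compounds alone, 3-chloro-4-nitrophenyl in place of 5-chloro-2-hydroxyphenyl on a carbonyl carbon gives a 10-fold lower number from compound 2 to compound 3 (1.00 log units; beyond the scatter), the only single-place step in this set. It shows that the number responds, beyond the scatter, to the group held at this position. No evidence at hand accounts for this step.

The compounds shown leave open whether the entering nitro or the departing hydroxy carries the step, as the two change together. As far as these compounds go, whether an amine in place of the nitro would keep the lower number also remains open.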